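Methyl on the Nitrogen: From Compound 3 to Compound 4

The compounds below may be only part of what the source reports. "The series", "measured", "known", "first", "only" and "open" are said of these compounds alone.

Measured compounds:
compound 1, `CC(C)c1onc(-c2c(Cl)cccc2Cl)c1COc1ccc(N(C)C(=O)c2ccc(C(=O)O)cc2)c(C(F)(F)F)n1`, 63%
compound 2, `CC(C)c1onc(-c2c(Cl)cccc2Cl)c1COc1ccc(NC(=O)c2ccc(C(=O)O)cc2)c(C(F)(F)F)n1`, 48%
compound 3, `CC(Nc1ccc(C(=O)O)cc1)c1ccc(OCc2c(-c3c(Cl)cccc3Cl)noc2C2CC2)nc1C(F)(F)F`, 49%

In a functional assay on HEK293 cells for agonist activity at Bile acid receptor (Homo sapiens), read by a luciferase reporter (a higher number here means a larger maximal response, a lower number a smaller maximal response), compound 1 gives 63% and compound 2 gives 48%. The two differ in one place, (methyl in place of hydrogen on an amide-type nitrogen), and this change gave a number 15 percentage points higher from compound 2 to compound 1 (beyond the scatter). Compound 3 gives 49% in this assay; the difference between its core and that of compound 2 is not broken down here.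

Compound 4, `CC(c1ccc(OCc2c(-c3c(Cl)cccc3Cl)noc2C2CC2)nc1C(F)(F)F)N(C)c1ccc(C(=O)O)cc1`, is not yet measured. It differs from compound 3 by methyl in place of hydrogen on a nitrogen on an aromatic ring. This is the same kind of change as that from compound 2 to compound 1, not the same: there the nitrogen was an amide-type nitrogen whose other neighbours are an aromatic carbon and a carbonyl carbon, here it is a nitrogen on an aromatic ring whose other neighbours are an aromatic carbon and a saturated chain carbon. For the measured compounds named here, only one such step is known, so the expectation rests on it alone. Compound 4 is expected to show a step of a number 11 percentage points higher from compound 3 to compound 4 (beyond the scatter) in this assay, guided by a number 15 percentage points higher from compound 2 to compound 1 (beyond the scatter). Compound 4 is therefore estimated at 60%, between 45% and 75%.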

Compound 4, largest response reached (reported as efficacy), in percent of the reference or control that the assay uses: 57%
The estimate for compound 4 lay 3 percentage points above the measured number, and the stated range covers the measured number.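

In this assay, methyl in place of hydrogen on the nitrogen on an aromatic ring gave a number 8 percentage points higher from compound 3 to compound 4 (within the scatter), so this step taken alone cannot be told apart from the scatter of repeated measurements. Set beside the same kind of change on the amide-type nitrogen, its size does not differ from the earlier step: the same change on two cores in this assay, a number 15 percentage points higher (beyond the scatter) from compound 2 to compound 1 and a number 8 percentage points higher (within the scatter) from compound 3 to compound 4, 7 percentage points apart, within the scatter of two such steps The two cores therefore give no sign that the size of the step depends on the core, but this does not establish that it carries over unchanged, as the comparison rests on only two pairs, the nitrogens are of different kinds, and only one step lies beyond the scatter.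

The compounds shown leave open what an ethyl group or a longer chain would give on either nitrogen in place of the methyl. They also leave open whether the methyl step would hold if a tetrazole stood in place of the carboxylic acid.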